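Changing the nitrogen substituent on a weakly cytotoxic series

The compounds below may be only part of what the source reports. "The series", "measured", "known", "first", "only" and "open" are said of these compounds alone.

In a functional assay on MDA-MB-231 cells (Homo sapiens) for cytotoxicity, read by cell counting, with a stated time of 48 h (on this read-out lower numbers stand for stronger inhibition and higher numbers for weaker inhibition), compound 1 `Clc1ccc(-n2cc(COc3cccc4cnc(Nc5cccc(Cl)c5)nc34)nn2)cc1` reaches only a limit of > 25000 nM and no actual number. Among the compounds with values here, compound 2 `Clc1cccc(Nc2ncc3cccc(OCc4cn(Cc5c(Cl)cccc5Cl)nn4)c3n2)c1` gives 21000 nM as the only actual number so far. Compound 3 `Clc1cccc(Nc2ncc3cccc(OCc4cn(-c5ccc(Br)cc5)nn4)c3n2)c1` differs from compound 2 by 4-bromophenyl in place of 2,6-dichlorobenzyl on an aromatic nitrogen on the same aromatic nitrogen. Within the data shown here, the only measured step at this place is an at least 1.1-fold lower number from compound 1 to compound 2 (0.07 log units; that floor lies within the scatter) and it stays within the scatter. On that basis, a 1.3-fold higher number from compound 2 to compound 3 (0.11 log units; within the scatter) is expected in this assay with no change beyond the scatter. For compound 3 the estimated value is 27000 nM with an expected range from 14000 nM to 50000 nM and a report of only a limit is quite possible.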

Compound 3, half-maximal inhibitory concentration: 33000 nM
Beside the measured number, compound 3's estimate is 1.2-fold (0.09 log units) below it; the measured number falls inside the stated range.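

Compound 3 gives this position its first step between two actual numbers: 4-bromophenyl in place of 2,6-dichlorobenzyl on the aromatic nitrogen gives a 1.6-fold higher number from compound 2 to compound 3 (0.20 log units; within the scatter) in this assay. So these two quite different halogen-bearing aromatic groups cannot be told apart here. Compound 1 gives only a limit, so its step to compound 3 cannot be read: the limit of > 25000 nM in this assay, at which 1 of the 3 values shown sits.

All three compounds carry a chlorine- or bromine-bearing aromatic ring at this nitrogen. Going by these compounds, whether an amine, a carboxylic acid or a longer alkyl chain there would shift the number beyond the scatter stays open.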